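Diarylmethylpiperidine series: aorta functional readout, step to compound 4

The source may report more compounds than this note shows. Statements on the series, on what has been measured and on what is new or still open speak of the compounds shown alone.

Measured so far:
compound 1 `COc1cc(C(C)=O)ccc1OCCCN1CCC(C(c2ccc(F)cc2)C2CCCCC2)CC1`, 5.01 nM
compound 2 `COc1cc(C(C)=O)ccc1OCCCN1CCC(C(O)(c2ccc(F)c(F)c2)c2ccc(F)c(F)c2)CC1`, 2.51 nM
compound 3 `COc1cc(C#N)ccc1OCCCN1CCC(C(c2ccc(F)cc2)c2ccc(F)cc2)CC1`, 2 nM

All three values come from a functional assay (aorta) with Oryctolagus cuniculus as the target; on this read-out higher numbers stand for weaker binding and lower numbers for tighter binding. Compound 3 gives 2 nM, the lowest of the three numbers. Compound 2 sits nearest, and its value lies within the scatter of that of compound 3, so no order between these two can be read. Compound 1 sits furthest, and its gap to compound 3 is beyond the scatter. No pair of these compounds differs in only one place, so no single step can be assigned to any one change.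

Compound 4 `O=S(=O)(CCCN1CCC(C(c2ccc(F)cc2)c2ccc(F)cc2)CC1)c1ccccc1` has not been measured. Compared with compound 3 the change is phenylsulfonyl in place of 4-cyano-2-methoxyphenoxy on a saturated chain carbon, three bonds along the chain from an amine nitrogen in a ring. The 4-cyano-2-methoxyphenoxy group is present in compound 3 and a related substituted phenoxy group in compounds 1 and 2, so nothing measured here tells what happens when that ring is replaced by phenylsulfonyl. The expectation for this assay is a step in the direction of weaker binding, somewhat beyond the scatter, a 5.0-fold higher number from compound 3 to compound 4 (0.70 log units; beyond the scatter). For compound 4 the estimate in this assay is 10 nM, with a range from 2 nM to 50 nM.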

Compound 4, dissociation constant: 20 nM
Beside the measured number, compound 4's estimate is 2.0-fold (0.30 log units) below it, and the stated range covers the measured number.
By their numbers in this assay, from the lowest: compounds 3, 2 and 1 (each within the scatter of the next, the first and the last beyond it); then compound 4.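

In this assay, for the compounds shown here, phenylsulfonyl in place of 4-cyano-2-methoxyphenoxy on a saturated chain carbon, three bonds along the chain from an amine nitrogen in a ring, gives a 10-fold higher number from compound 3 to compound 4 (1.00 log units; beyond the scatter), the only single-place step available. This step lies beyond the scatter, so on this shared core the read-out depends on the group at this position, and this exchange moves it towards weaker binding. Nothing at hand explains the step.

The exchange replaces the linking oxygen, the ring substituents and the sulfonyl unit in one move, so the part responsible remains unassigned. From the compounds shown here alone, an unsubstituted phenoxy group or a 4-cyanophenylsulfonyl group would separate these contributions, and whether the step carries over to the cores of compound 1 and compound 2 remains open.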